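The compounds below may be only part of what the source reports. "The series", "measured", "known", "first", "only" and "open" are said of these compounds alone.

Working notes on the series in a functional assay on RXF 393 cells (Homo sapiens) for inhibition; on this read-out higher numbers stand for weaker inhibition of growth and lower numbers for stronger inhibition of growth. Compound 1 `CC(=O)CC/C=C(\C)CCC1=C(C)CCCC1(C)C` is the open-chain member; in this assay compound 1 gives only a limit, > 15000 nM. Compound 2 `C=C1CCCC(C)(C)C1CC[C@]1(C)CC[C@@H]([C@@H](C)C(=O)O)OO1` carries the cyclic peroxide and the acid side chain on a single ring; in this assay compound 2 likewise gives only a limit, > 10000 nM. Compound 3 `C=C1CCC[C@H]2[C@](C)(CC[C@]3(C)CC[C@@H]([C@@H](C)C(=O)O)OO3)[C@@H](C)CC[C@]12C` holds the same peroxide and acid on a larger fused core; in this assay compound 3 gives a number, 2950 nM. For the measured compounds named here, compound 2 therefore stands at a limit and not at a number, and of the three values shown one further value is also a limit (the limit of > 15000 nM in this assay, at which 1 of the 3 values shown sits); the only number in the set belongs to compound 3.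

Compound 4 `C=C1CCCC(C)(C)C1CC[C@@]1(C)CC[C@H]([C@@H](C)C(=O)O)OO1` is the next member: the two compounds have the same atoms and bonds; at least one stereo element is drawn with a configuration in one of them and without one in the other: 2 of 4 stereo elements differ; a stereocentre at a saturated ring carbon is drawn R in compound 2 and S in compound 4; a stereocentre at a saturated ring carbon is drawn S in compound 2 and R in compound 4. Going by the values given here, no measured step between two compounds that differ in one place is available, so no size can be read off for a change of this kind. Compound 2 sits at the limit of > 10000 nM in this assay, at which 1 of the 3 values shown sits, and a change confined to two ring stereocentres gives no ground to expect a move beyond the scatter in either direction. Compound 4 is expected to give about 10000 nM in this assay, within 3500 nM to 25000 nM. The expected step is a number no higher from compound 2 to compound 4 (the limit leaves the size open), none beyond the usual scatter, with a fair chance that only a limit is reported again.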

Compound 4, concentration for 50% growth inhibition: 5040 nM
Compound 4: the middle estimate sits 2.0-fold (0.30 log units) above what was measured; low and high end bracket the measured number.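

In this assay, for the compounds shown here, the change of drawn configuration at two ring stereocentres is the first change that can be read as a step, and it gives an at least 1.9-fold lower number from compound 2 to compound 4 (0.29 log units; that floor lies within the scatter). With atoms and bonds unchanged, compound 4 gives a number rather than a limit, so the single-ring peroxide with the acid side chain is not confined to a limit in every configuration drawn. The true size of the step stays open because the starting point of compound 2 is a limit, and the floor of the step does not clear the usual scatter: the limit of > 10000 nM in this assay, at which 1 of the 4 values shown sits.

The compounds shown leave open whether the same change of configuration at the peroxide ring would shift the value of compound 3 on its larger fused core, and whether the stereocentre of the acid side chain, the same in compound 2 and compound 4, matters at all. They also leave open whether a methyl ester or an amide in place of the carboxylic acid would keep the growth inhibition seen for compound 4 in this assay.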